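The compounds below may be only part of what the source reports. "The series", "measured", "known", "first", "only" and "open" are said of these compounds alone.

Compound 1 `C=C1C(=O)[C@]23C[C@@]1(O)CC[C@H]2c1ccc(O)c(C)c1[C@@H]3Cn1cc(-c2ccc(C(F)(F)F)cc2)nn1`: in a functional assay on SW480 cells (Homo sapiens) for cytotoxicity, read by MTT assay, with a stated time of 4 days (a higher number here means a weaker inhibitor, a lower number a stronger inhibitor), compound 1 gives 370 nM.
Compound 2 `C=C1C(=O)[C@]23C[C@@]1(O)CC[C@H]2c1ccc(O)c(C)c1[C@@H]3Cn1cc(-c2ccc(C)cc2)nn1`: in this assay compound 2 gives 330 nM.
Compound 3 `C=C1C[C@]23C[C@@]1(O)CC[C@@H]2c1cccc(C)c1[C@@H]3Cn1cc(-c2ccc(C(F)(F)F)cc2)nn1`: in this assay compound 3 gives only a limit, > 20000 nM.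

Compounds 1 and 2 share one core, compounds 3 and 4 another; the difference between the two cores is not broken down here. From compound 1 to compound 2 the change is methyl in place of trifluoromethyl on an aromatic carbon, and the step it made is a 1.1-fold lower number from compound 1 to compound 2 (0.05 log units; within the scatter). Compound 4 `C=C1C[C@]23C[C@@]1(O)CC[C@@H]2c1cccc(C)c1[C@@H]3Cn1cc(-c2ccc(C)cc2)nn1` is not yet measured in this assay. It differs from compound 3 by methyl in place of trifluoromethyl on an aromatic carbon, the same change at the same place. Compound 3 sits at the limit of > 20000 nM in this assay, at which 1 of the 3 values shown sits. Because a 1.1-fold lower number from compound 1 to compound 2 (0.05 log units; within the scatter) lies within the scatter, compound 4 is expected to make a step of a number no higher from compound 3 to compound 4 (the limit leaves the size open). Compound 4 is therefore estimated at 20000 nM, between 8000 nM and 60000 nM, most probably reported again only as a limit.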

Compound 4, half-maximal inhibitory concentration: > 20000 nM
Compound 4: no number, only a limit; the forecaster's own chance of this, stated with the estimate: 85%; the middle value sits exactly at the limit.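

Compound 3 and compound 4 are both reported only as limits in this assay, so no step between them can be read: the limit of > 20000 nM in this assay, at which 2 of the 4 values shown sit.

The compounds shown leave open how far either lies past that limit, and whether changing trifluoromethyl to methyl matters on their core.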